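The source may hold more compounds than are shown below. What is called first, only, known or untested is meant among the compounds shown, and "the series" means these compounds.

Measured so far:
- compound 1, `CC(C)OCc1nc(Nc2ccc(C(F)(F)F)cc2)c2ccc(-c3ncccc3C(F)(F)F)cc2n1`: 0.3 nM
- compound 2, `OCCCc1nc(Nc2ccc(C(F)(F)F)cc2)c2ccc(-c3ncccc3C(F)(F)F)cc2n1`: 25 nM

Compound 1 and compound 2 share a core and differ only in the group carried on a saturated chain carbon bound to an aromatic carbon. In a functional assay for antagonist activity at transient receptor potential cation channel subfamily V member 1 (Homo sapiens) (a lower number here means a stronger inhibitor, a higher number a weaker inhibitor), compound 1 gives 0.3 nM, while compound 2 gives 25 nM. Going by the values given here, the step of an 83-fold higher number from compound 1 to compound 2 (1.92 log units; beyond the scatter) is the only measured step, and it shows that this position is sensitive to what sits on it. Among the compounds with values here, compound 2 stands highest of the two numbers, with compound 1 its only neighbour.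

Compound 3, `CNCc1nc(Nc2ccc(C(F)(F)F)cc2)c2ccc(-c3ncccc3C(F)(F)F)cc2n1`, is the next compound in this line. It differs from compound 2 by methylamino in place of 2-hydroxyethyl on a saturated chain carbon bound to an aromatic carbon. Within the data shown here, no measured step involves methylamino, so only the size of the step from compound 1 to compound 2 bears on this change: a small group at this carbon moved the number by a large amount. The new group is again small and keeps one hydrogen-bond donor and one acceptor, so a shift back toward the number of compound 1 is expected, though less than the whole way. For compound 3 the expected step is a 3.1-fold lower number from compound 2 to compound 3 (0.49 log units; beyond the scatter), and its estimated value in this assay is 8 nM, with a range from 1 nM to 60 nM.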

Compound 3, half-maximal inhibitory concentration: 26 nM
For compound 3 the middle estimate is 3.3-fold (0.51 log units) below the measured one, and the stated range covers the measured number.
By their numbers in this assay, from the lowest: compound 1; then compounds 2 and 3 (each within the scatter of the next).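

In this assay, methylamino in place of 2-hydroxyethyl on a saturated chain carbon bound to an aromatic carbon gives a 1.0-fold higher number from compound 2 to compound 3 (0.02 log units; within the scatter) and so leaves the number unchanged within the scatter, even though the two groups differ in heavy atoms and carry nitrogen rather than oxygen. Methylamino in place of isopropoxy gives an 87-fold higher number from compound 1 to compound 3 (1.94 log units; beyond the scatter) in the same assay, so a second group with the same count of hydrogen-bond donors and acceptors as 2-hydroxyethyl also stays far from compound 1, which until now had been compared with only one group. Nothing available here accounts for the match between these two groups or for the gap to isopropoxy.

The compounds shown leave open which part of isopropoxy goes with the low number of compound 1, a question that a methoxy or an ethoxy group at this carbon would address. They also leave open whether the match between compound 2 and compound 3 would hold for a dimethylamino group or a carboxylic acid in the same place.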